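This account rests on a few compounds, and the source may have more. Where it says the series, first, only, none or still open, it means among the compounds named here.

Working notes on the series. In an ADME assay on NHDF cells (Homo sapiens) for cytotoxicity, read by MTT assay, with a stated time of 72 h (on this read-out higher numbers stand for weaker inhibition and lower numbers for stronger inhibition), compound 1 `COc1cccc(/C=C2\CCC/C(=C\c3ccc(O)cc3)C2=O)c1OC` returns only a limit, > 50000 nM. Among the compounds with values here, compound 2 `COc1cc(/C=C2\CCC/C(=C\c3cccc(OC)c3OC)C2=O)ccc1O` gives 14300 nM, the only true number so far. Within the data shown here, the single measured step is an at least 3.4-fold lower number from compound 1 to compound 2 (0.54 log units; beyond the scatter), where methoxy replaced hydrogen on an aromatic carbon. Compound 3 `COc1cccc(/C=C2\CCC/C(=C\c3ccc(O)c(O)c3)C2=O)c1OC` alters that same methoxy: hydrogen in place of methyl on an oxygen on an aromatic ring. The oxygen stays, so only a small change in this assay is expected, with no firm direction and nothing beyond the scatter, though an at least 3.4-fold lower number from compound 1 to compound 2 (0.54 log units; beyond the scatter) shows this group can matter. The expected change is a 1.2-fold lower number from compound 2 to compound 3 (0.08 log units; within the scatter). The estimate for compound 3 is 12000 nM, with an expected range of 4000 nM to 40000 nM.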

Compound 3, half-maximal inhibitory concentration: 17900 nM
For compound 3 the middle estimate is 1.5-fold (0.17 log units) below the measured one, within the range that was stated.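

In this assay hydrogen in place of methyl on the oxygen gives a 1.3-fold higher number from compound 2 to compound 3 (0.10 log units; within the scatter) and so separates hydroxy from methoxy at this position no more than repeated measurements would. A hydroxy where hydrogen stood gives an at least 2.7-fold lower number from compound 1 to compound 3 (0.44 log units; beyond the scatter) and so, like methoxy, stands apart from hydrogen here. That step has only one firm end, since compound 1 stands at a limit of the assay: the limit of > 50000 nM in this assay, at which 1 of the 3 values shown sits.

As far as these compounds go, whether an amine or a longer chain such as ethoxy at this position would read like hydroxy and methoxy stays open.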